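A few compounds are considered here, and "the series" means these few. Any claim that something is new, unique, unknown or untested is made for them only; others in the source may bear on it.

Measured compounds:
compound 1 `CCN(Cc1ccoc1)C(=O)COc1ccc(C)cc1` — 136 nM
compound 2 `Cc1ccc(OCC(=O)N(Cc2cccs2)c2ncccn2)cc1` — 3700 nM
compound 3 `CCc1ccc(OCC(=O)N(CC)Cc2cccs2)cc1` — 67 nM

All three numbers come from an assay on HEK293 cells for agonist activity at transient receptor potential cation channel subfamily M member 8 (Homo sapiens), read by fluorescence and calcium flux, with a stated time of 15 min; a lower number here means that less compound is needed, a higher number that more compound is needed for the effect. Compound 1 stands second highest of the three. Its nearest neighbour is compound 3, which gives 67 nM, a lower number than compound 1 and one that lies beyond the scatter. Furthest off is compound 2, which with 3700 nM gives a much higher number than compound 1, well beyond the scatter. Going by the values given here, no single-change pair among the measured compounds is available, so no measured step anchors the next move.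

Compound 4 `CCN(Cc1ccccc1)C(=O)COc1ccc(C)cc1` is not yet measured in this assay. Against compound 1 it differs in one place: phenyl in place of furan-3-yl on a saturated chain carbon bound to an amide-type nitrogen. Among the compounds with values here, there is no measured pair in the set that isolates this exchange, so the size of the step has to be guessed from the general level of compound 1 and compound 3 alone. The expectation is for no step beyond the scatter, with at most a small movement toward a lower number.

Compound 4 is thus expected to give about 110 nM in this assay, within a range of 40 nM to 350 nM. The estimated step of a 1.2-fold lower number from compound 1 to compound 4 (0.09 log units; within the scatter) is meant as an expectation, not a measurement.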

Compound 4, half-maximal effective concentration: 1880 nM
For compound 4 the middle estimate is 17-fold (1.23 log units) below the measured one; the measured number lies above the stated range.
By their numbers in this assay, from the lowest: compound 3; then compound 1; then compounds 4 and 2 (each within the scatter of the next).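

In this assay, going by these compounds alone, phenyl in place of furan-3-yl on a saturated chain carbon bound to an amide-type nitrogen gives a 14-fold higher number from compound 1 to compound 4 (1.14 log units; beyond the scatter), the first single-change step and a large one. With the rest of the core of compound 1 held constant, the number at this position therefore depends strongly on which aromatic ring is carried there. The exchange removes a five-membered aromatic ring with 1 hetero atom and 1 hydrogen-bond acceptor and brings in a six-membered aromatic ring of carbon only with 0 hydrogen-bond acceptors, so ring size and the ring oxygen change together and this single step cannot separate them.

Going by these compounds, it remains open whether a pyridin-3-yl ring, which keeps the six-membered size but carries a ring nitrogen, would stay closer to compound 1 at 136 nM or to compound 4 at 1880 nM. Also open, on these data alone, is whether a saturated ring such as tetrahydrofuran-3-yl or cyclohexyl would be tolerated at this position. No measurement at hand explains the size of this step.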